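This account rests on a few compounds, and the source may have more. Where it says the series, first, only, none or still open, it means among the compounds named here.

Measured so far: compound 1 `O=S(=O)(NCCCNc1nccc(-c2c(-c3cccc(F)c3)nc3sccn23)n1)c1ccc(Br)cc1` gives 7040 nM in a functional assay on A-375 cells (Homo sapiens) for cytotoxicity, read by MTT assay; on this read-out higher numbers stand for weaker inhibition and lower numbers for stronger inhibition; compound 2 `O=S(=O)(NCCNc1nccc(-c2c(-c3cccc(F)c3)nc3sccn23)n1)c1ccc(Br)cc1` gives 13500 nM; compound 3 `O=S(=O)(NCCCNc1nccc(-c2c(-c3cccc(F)c3)nc3sccn23)n1)c1ccc(C(F)(F)F)cc1` gives 4090 nM.

Compound 2 has the highest of the three numbers, though its gap to compound 1 stays within the scatter and only its gap to compound 3 lies beyond it. Compound 4 `O=S(=O)(NCCCNc1nccc(-c2c(-c3cccc(F)c3)nc3sccn23)n1)c1ccc(Cl)cc1` differs from compound 2 by (((4-chlorophenyl)sulfonyl)amino)methyl in place of ((4-bromophenyl)sulfonyl)amino on a saturated chain carbon, two bonds along the chain from a nitrogen on an aromatic ring. For the measured compounds named here, two measured steps bear on this change. The chain extension reverses the step of a 1.9-fold higher number from compound 1 to compound 2 (0.28 log units; within the scatter). The swap at the aromatic carbon has no direct parallel, but the step of a 1.7-fold lower number from compound 1 to compound 3 (0.24 log units; within the scatter) shows that exchanging bromo for another group moved the number little. For compound 4 the expected step is therefore a 1.8-fold lower number from compound 2 to compound 4 (0.26 log units; within the scatter), landing near compound 1. Compound 4 is thus estimated at 7500 nM, expected between 3000 nM and 18000 nM.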

Compound 4, half-maximal inhibitory concentration: 5900 nM
For compound 4 the middle estimate is 1.3-fold (0.10 log units) above the measured one; measured number inside the range.
By their numbers in this assay, from the lowest: compounds 3, 4, 1 and 2 (each within the scatter of the next, the first and the last beyond it).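

Chloro, bromo and trifluoromethyl on the aromatic carbon cannot be told apart in this assay: the steps are a 1.2-fold lower number from compound 1 to compound 4 (0.08 log units; within the scatter) and a 1.4-fold higher number from compound 3 to compound 4 (0.16 log units; within the scatter). For the compounds shown here, the only new step beyond the scatter is a 2.3-fold lower number from compound 2 to compound 4 (0.36 log units; beyond the scatter), and this change replaces bromo with chloro and adds the methyl carbon at once, so the compounds cannot divide the effect between the two. Nothing available explains these numbers.

Going by these compounds, whether an amine or a carboxylic acid on the aromatic carbon would move the number remains open. So does the effect of a longer chain than that of compound 4.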